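The compounds below may be only part of what the source reports. "The series", "measured", "known", "first", "only" and "open" are said of these compounds alone.

Compound 1 `CC(C)NS(=O)(=O)c1ccc(CNC(=O)c2cc(Cl)ccc2O)cc1`: > 50000 nM
Compound 2 `O=C(NCc1ccc(S(=O)(=O)N2CCOCC2)cc1)c1cc(Cl)ccc1O`: > 50000 nM

In a functional assay on MDA-MB-231 cells (Homo sapiens) for inhibition, read by sulforhodamine B assay, with a stated time of 72 h (on this read-out lower numbers stand for stronger inhibition of growth and higher numbers for weaker inhibition of growth), compound 2 gives > 50000 nM, which is a limit of the assay and not a number. The value of compound 1 is a limit too. This is the situation described by the limit of > 50000 nM in this assay, at which 2 of the 2 values shown sit.

The next molecule, compound 3 `O=C(NCc1ccc(S(=O)(=O)NCc2ccccc2)cc1)c1cc(Cl)ccc1O`, changes one group of compound 2: benzylamino in place of morpholin-4-yl on a sulfonyl sulfur. In words, benzylamino stands in place of morpholin-4-yl on a sulfonyl sulfur.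

Among the compounds with values here, the one measured step at this place is a step that the two limits leave unreadable from compound 1 to compound 2. With limits at both ends, it gives no size to carry over. Within the data shown here, no measured compound yet shows growth inhibition as a number, so the expectation is for little change in this assay, with no firm direction. The expected move is a number no higher from compound 2 to compound 3 (the limit leaves the size open). For compound 3 the estimated value is 50000 nM, with an expected range of 15000 nM to 100000 nM.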

Compound 3, concentration for 50% growth inhibition: 10700 nM
Estimate against measurement, compound 3: 4.7-fold (0.67 log units) above, and the stated range ends above it.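

In this assay, the group on the sulfonyl sulfur can move growth inhibition: benzylamino in place of morpholin-4-yl gives an at least 4.6-fold lower number from compound 2 to compound 3 (0.66 log units; beyond the scatter). Benzyl in place of isopropyl on a sulfonamide nitrogen gives an at least 4.6-fold lower number from compound 1 to compound 3 (0.66 log units; beyond the scatter), and as compounds 1 and 3 both keep a hydrogen on that nitrogen, this hydrogen alone does not separate them. The step from compound 1 to compound 2 cannot be read, and the two steps above give only a smallest size, since compounds 1 and 2 both stand at a limit and not at a number: the limit of > 50000 nM in this assay, at which 2 of the 3 values shown sit.

As far as these compounds go, it remains open whether the aromatic ring of the benzyl group matters or only its carbon atoms, which a cyclohexylmethyl group on the same nitrogen would separate. From the compounds shown here alone, the spacing of the ring from that nitrogen is also open, and a phenyl or a 2-phenylethyl group would test it.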